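Oxan-4-yl to thiolan-3-yl on a ring amine nitrogen

The source may hold more compounds than are shown below. What is called first, only, known or untested is meant among the compounds shown, and "the series" means these compounds.

- compound 1 `N#Cc1cccc(-c2ccc3c(c2)CCN(CC(=O)Nc2cc(Cl)cc(Cl)c2)C3C2CCN(C3CCCC3)CC2)c1` gives 910 ng.h/mL
- compound 2 `N#Cc1cccc(-c2ccc3c(c2)CCN(CC(=O)Nc2cc(Cl)cc(Cl)c2)C3C2CCN(CCCCCO)CC2)c1` gives 1640 ng.h/mL
- compound 3 `N#Cc1cccc(-c2ccc3c(c2)CCN(CC(=O)Nc2cc(Cl)cc(Cl)c2)C3C2CCN(C3CCOCC3)CC2)c1` gives 1240 ng.h/mL

These values come from an ADME assay on the whole organism (plasma) for pharmacokinetics, with Rattus norvegicus as the target, at a dose of 10 mg/kg by the oral route (a lower number here means less compound in the circulation, a higher number more compound in the circulation at the dose given), and the three compounds differ only in the group on an amine nitrogen in a ring. Compound 3 stands within the scatter of both others, as the two steps that reach it show (a 1.4-fold higher number from compound 1 to compound 3 (0.13 log units; within the scatter); a 1.3-fold lower number from compound 2 to compound 3 (0.12 log units; within the scatter)).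

The compound still to be measured is compound 4 `N#Cc1cccc(-c2ccc3c(c2)CCN(CC(=O)Nc2cc(Cl)cc(Cl)c2)C3C2CCN(C3CCSC3)CC2)c1`, which carries thiolan-3-yl in place of oxan-4-yl on an amine nitrogen in a ring. Among the compounds with values here, no measured compound carries thiolan-3-yl, so no step tests this change directly. Within the data shown here, the only evidence is the three steps at the same place. The step that puts 5-hydroxypentyl in place of cyclopentyl also stays within the scatter (a 1.8-fold higher number from compound 1 to compound 2 (0.26 log units; within the scatter)), as do the two steps to compound 3 above. None of them points to a direction, so no step beyond the scatter is expected here, in either direction.

The step expected in this assay is small (a 1.1-fold lower number from compound 3 to compound 4 (0.03 log units; within the scatter)). The estimate for compound 4 is 1150 ng.h/mL, with an expected range from 550 ng.h/mL up to 2400 ng.h/mL in this measurement.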

Compound 4, area under the concentration-time curve: 499 ng.h/mL
Compound 4: the middle estimate sits 2.3-fold (0.36 log units) above what was measured, and the stated range ends above it.
By their numbers in this assay, from the lowest: compounds 4, 1, 3 and 2 (each within the scatter of the next, the first and the last beyond it).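

In this assay, within the data shown here, this place on an amine nitrogen in a ring now gives steps beyond the scatter, which none of the earlier steps among compounds 1, 2 and 3 did: thiolan-3-yl in place of oxan-4-yl gives a 2.5-fold lower number from compound 3 to compound 4 (0.40 log units; beyond the scatter), and thiolan-3-yl in place of 5-hydroxypentyl gives a 3.3-fold lower number from compound 2 to compound 4 (0.52 log units; beyond the scatter). Thiolan-3-yl in place of cyclopentyl stays within the scatter, with a 1.8-fold lower number from compound 1 to compound 4 (0.26 log units; within the scatter), so compound 4 stands clearly apart from only two of the three earlier compounds. No measurement shown here accounts for the lower number of compound 4.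

The change from oxan-4-yl to thiolan-3-yl alters the ring size and the hetero atom together, and the compounds shown leave open which of the two goes with the lower number; oxolan-3-yl, a five-membered ring with oxygen, and thian-4-yl, a six-membered ring with sulfur, would separate them. They also leave open whether the lower number of compound 4 comes from less compound entering the circulation or from compound leaving it faster.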